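Swapping bromo for chloro at the limit of cytotoxicity

This account rests on a few compounds, and the source may have more. Where it says the series, first, only, none or still open, it means among the compounds named here.

Compound 1 (`CNC(=O)c1cc(Oc2ccc(NC(=O)c3cc(-c4ccc(C)cc4)ncn3)cc2)ccn1`) and compound 2 (`CNC(=O)c1cc(Oc2ccc(NC(=O)c3cc(-c4ccc(Br)cc4)ncn3)cc2)ccn1`) differ in one aromatic substituent. In a functional assay on A549 cells (Homo sapiens) for cytotoxicity, read by MTT assay, with a stated time of 72 h (on this read-out higher numbers stand for weaker inhibition and lower numbers for stronger inhibition), compound 1 gives > 100000 nM as a limit of the assay and not a number. In this assay compound 2 gives > 100000 nM as a limit of the assay as well, so no number is available for it. The two compounds therefore stand together (the limit of > 100000 nM in this assay, at which 2 of the 2 values shown sit). Among the compounds with values here, the one measured step (a step that the two limits leave unreadable from compound 1 to compound 2) puts bromo in place of methyl on an aromatic carbon.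

Compound 3 (`CNC(=O)c1cc(Oc2ccc(NC(=O)c3cc(-c4ccc(Cl)cc4)ncn3)cc2)ccn1`) carries chloro in place of bromo on an aromatic carbon para to a large group. Within the data shown here, with the only measured step (a step that the two limits leave unreadable from compound 1 to compound 2) offering no size to carry forward, no step beyond the scatter is expected in this assay and no direction is assigned. The expected step (a number no higher from compound 2 to compound 3 (the limit leaves the size open)) is estimated to stay within the scatter, and another limit is the likeliest report. Compound 3 is estimated at 100000 nM with 40000 nM and 200000 nM as the lower and upper ends of the expected range.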

Compound 3, half-maximal inhibitory concentration: > 100000 nM
Compound 3: only a limit was reported; the forecaster's own chance of this, stated with the estimate: 85%; the middle value lies on the limit itself.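

In this assay compound 3 gives > 100000 nM, which is a limit of the assay and not a number. The steps among compound 1, compound 2 and compound 3 therefore cannot be read, and the three stand together: the limit of > 100000 nM in this assay, at which 3 of the 3 values shown sit. The compounds shown leave open whether any substituent at this place would give a number in this assay.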